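Swapping an Amino Group for Fluorine on a Chalcone

The source may hold more compounds than are shown below. What is called first, only, known or untested is meant among the compounds shown, and "the series" means these compounds.

This short series concerns compounds with a shared core, a chain bearing a carbonyl that links two six-membered aromatic rings. Compound 1 has the structure `COc1cc(O)ccc1/C=C/C(=O)c1ccc(N)cc1`. In an assay on isolated protein for inhibition of DNA topoisomerase 1 (Homo sapiens), tested at 20 uM (on this read-out higher numbers stand for a stronger effect at the one concentration tested and lower numbers for a weaker effect), compound 1 gives "not determined" (no result reported), so there is no single number on which it stands; all that exists for this core is the result of its relative compound 2, with the structure `O=C(/C=C/c1ccc(N2CCCC2)cc1)c1ccc(O)cc1O`, which in this assay gives 64.4%. Compound 2 carries different groups on both rings, so its value can only hint at the range the core can reach, not at what compound 1 would have shown.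

Compound 3, with the structure `COc1cc(O)ccc1/C=C/C(=O)c1ccc(F)cc1`, differs from compound 1 in one place: fluoro in place of amino on an aromatic carbon. Within the data shown here, no measured pair in this set makes this same change, so no step can be quoted. For this assay the expectation is therefore open: a change of either direction, or none beyond the scatter, remains possible. On that basis compound 3 is estimated to give 35%, within a range from 5% to 70%.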

Compound 3, a percentage reported as inhibition, at one concentration (the size of the read-out at that concentration, not a potency): 9.5%
Estimate against measurement, compound 3: 25.5 percentage points above, within the range that was stated.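

In this assay, among these compounds, compound 3 gives 9.5%, but compound 1 has no single number there, so no step between compound 1 and compound 3 can be read. No available evidence bears on this result. From the compounds shown here alone, whether fluoro in place of amino strengthens, weakens or leaves unchanged the effect on this shared core remains open.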